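Replacing the cyano group of compound 3

A few compounds are considered here, and "the series" means these few. Any claim that something is new, unique, unknown or untested is made for them only; others in the source may bear on it.

In a functional assay on EBC-1 cells (Homo sapiens) for antiproliferative activity, with a stated time of 72 h (on this read-out lower numbers stand for stronger inhibition and higher numbers for weaker inhibition), compound 1 `OCCn1cc(-c2cc(F)c3ncc(Cc4ccc5ncccc5c4)n3c2)cn1` gives 0.34 nM. Compound 2 `N#Cc1ccc(-c2cc(F)c3ncc(Cc4ccc5ncccc5c4)n3c2)cn1` gives 189 nM, and compound 3 `N#Cc1ccc(-c2cc(F)c3ncc(Cc4ccc5ncccc5c4)n3c2)cc1F` gives 145 nM. Compound 3 thus stands level with compound 2 and far from compound 1.

Compound 4 `O=C(c1ccc(-c2cc(F)c3ncc(Cc4ccc5ncccc5c4)n3c2)cc1F)N1CCC2(COC2)C1` has not yet been measured. It differs from compound 3 in one place: a group of 10 heavy atoms (7 carbon, 1 nitrogen, 2 oxygen; one four-membered non-aromatic ring with 1 hetero atom, one five-membered non-aromatic ring with 1 hetero atom) in place of a group of 2 heavy atoms (1 carbon, 1 nitrogen; no ring), on an aromatic carbon. The change sits on an aromatic carbon, ortho to a fluoro group.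

The nearest evidence comes from replacing the whole aromatic group that carries the cyano: a 560-fold higher number from compound 1 to compound 2 (2.74 log units; beyond the scatter) and a 430-fold higher number from compound 1 to compound 3 (2.63 log units; beyond the scatter), both large. By contrast, a 1.3-fold lower number from compound 2 to compound 3 (0.12 log units; within the scatter) keeps a cyano group and stays within the scatter. Within the data shown here, of these three compounds, only the one without a cyano group has a low number. Among the measured compounds shown here, no measured compound carries the entering group, so the size of the step remains uncertain.

The expected step in this assay is toward a lower number, estimated as a 24-fold lower number from compound 3 to compound 4 (1.38 log units; beyond the scatter). For compound 4 the estimate is 6 nM, with an expected range from 0.6 nM to 70 nM.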

Compound 4, half-maximal inhibitory concentration: 406 nM
Beside the measured number, compound 4's estimate is 68-fold (1.83 log units) below it; measured number above the stated range.
By their numbers in this assay, from the lowest: compound 1; then compounds 3 and 2 (each within the scatter of the next); then compound 4.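

In this assay, taking away the cyano group at this place on the ring does not by itself lower the number: the change to the two-ring group of 10 heavy atoms gives a 2.8-fold higher number from compound 3 to compound 4 (0.45 log units; beyond the scatter). Compound 4 carries no cyano group, yet its number stays far from that of compound 1 at 0.34 nM, so the earlier picture, in which only the compound without a cyano group had a low number, does not hold as a general rule. No measurement on these compounds accounts for the rise in the number.

Going by these compounds, it remains open how a carboxylic acid, a primary amine or a 2-hydroxyethyl chain at this same place would compare. On these data alone, it is also open whether a simpler amide without the two non-aromatic rings would give a number closer to that of compound 3 or to that of compound 4.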